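Aryloxy variation and PBMC cytotoxicity in the series

The source may report more compounds than this note shows. Statements on the series, on what has been measured and on what is new or still open speak of the compounds shown alone.

Measured in an ADME assay on PBMC cells (Homo sapiens) for cytotoxicity; a lower number here means that less compound is tolerated, a higher number that more compound is tolerated:
compound 1 `CC(CCNC(=O)c1c(Cl)cncc1Cl)N1CCC(C(Oc2cccc(C(F)(F)F)c2)c2ccc(C(F)(F)F)cc2)CC1` gives 7000 nM
compound 2 `Cc1cccnc1OC(c1ccc(C(F)(F)F)cc1)C1CCN(C(C)CCNC(=O)c2c(Cl)cncc2Cl)CC1` gives 33000 nM
compound 3 `CC(CCNC(=O)c1c(Cl)cncc1Cl)N1CCC(C(Oc2cc(Cl)ccn2)c2ccc(C(F)(F)F)cc2)CC1` gives 4260 nM

Compound 3 has the lowest number of the three in this assay, yet its gap to compound 1 is within the scatter (a 1.6-fold lower number from compound 1 to compound 3 (0.22 log units; within the scatter)), while the gap to compound 2 is beyond it (a 7.7-fold lower number from compound 2 to compound 3 (0.89 log units; beyond the scatter)).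

Compound 4 `CC(CCNC(=O)c1c(Cl)cncc1Cl)N1CCC(C(Oc2ccccc2C#N)c2ccc(C(F)(F)F)cc2)CC1` differs from compound 3 by 2-cyanophenyl in place of 4-chloropyridin-2-yl on an oxygen on a saturated carbon. Among the measured compounds shown here, the nearest precedent is the exchange at the same oxygen from compound 1 to compound 3, which stayed within the scatter, whereas the pyridyl-to-pyridyl exchange from compound 2 to compound 3 moved the number more. For the measured compounds named here, no measured step carries a nitrile. A step of no more than modest size is therefore expected: a 1.4-fold higher number from compound 3 to compound 4 (0.15 log units; within the scatter). Compound 4 is estimated at 6000 nM, between 2500 nM and 15000 nM.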

Compound 4, half-maximal cytotoxic concentration: 17000 nM
Estimate against measurement, compound 4: 2.8-fold (0.45 log units) below, outside the stated range (above it).
By their numbers in this assay, from the lowest: compounds 3 and 1 (each within the scatter of the next); then compounds 4 and 2 (each within the scatter of the next).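

At this oxygen, a carbon-only aromatic ring does not fix the number in this assay: a 2.4-fold higher number from compound 1 to compound 4 (0.39 log units; beyond the scatter). The 2-cyanophenyl group also separates from one pyridyl group but not the other, with a 4.0-fold higher number from compound 3 to compound 4 (0.60 log units; beyond the scatter) and a 1.9-fold lower number from compound 2 to compound 4 (0.29 log units; within the scatter), so ring type does not sort these four compounds. No available evidence bears on the reason for these differences.

Open, as far as these compounds go, is how an unsubstituted phenyl at this oxygen would read against these groups. Also open, from the compounds shown here alone, is whether a phenyl carrying an amine or a carboxylic acid would keep the number of compound 4.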